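The source may hold more compounds than are shown below. What is called first, only, known or untested is meant among the compounds shown, and "the series" means these compounds.

Compound 1 `CCCCCCCCc1cn(C(c2ccccc2)c2cc3cc(Br)ccc3nc2OC)nn1` carries an octyl chain on the shared core. In an ADME assay on PC-3 cells (Homo sapiens) for cytotoxicity, read by sulforhodamine B assay, with a stated time of 48 h, tested at 10 uM (on this read-out lower numbers stand for less inhibition and higher numbers for more inhibition at the one concentration tested (going by the name of the read-out)), compound 1 gives 2.27%, the lowest of the three numbers in hand. Compound 2 `COc1nc2ccc(Br)cc2cc1C(c1ccccc1)n1cc(CCCO)nn1` gives 14.7%, and compound 3 `CCCc1cn(C(c2ccccc2)c2cc3cc(Br)ccc3nc2OC)nn1` gives 8.3%. Among the three, the step of a number 12.4 percentage points higher from compound 1 to compound 2 (beyond the scatter) is the only one that clears the usual scatter; the step of a number 6 percentage points higher from compound 1 to compound 3 (within the scatter) and the step of a number 6.4 percentage points lower from compound 2 to compound 3 (within the scatter) both fall within it.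

Compound 4 `COc1nc2ccc(Br)cc2cc1C(c1ccccc1)n1cc(CO)nn1` has not yet been measured in this assay. It differs from compound 1 by hydroxy in place of heptyl on a saturated chain carbon bound to an aromatic carbon. Among the compounds with values here, this change resembles the one from compound 1 to compound 2, where a hydroxy likewise replaced part of the chain, only here the cut sits closer to the core and removes more of the chain. The step of a number 12.4 percentage points higher from compound 1 to compound 2 (beyond the scatter) therefore bears on it most, with the step of a number 6 percentage points higher from compound 1 to compound 3 (within the scatter) as a smaller guide.

A modest rise is expected for compound 4, a step of a number 9.7 percentage points higher from compound 1 to compound 4 (within the scatter), giving an estimated 12% with a range from 2% to 24%.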

Compound 4, a percentage reported as inhibition, at one concentration (the size of the read-out at that concentration, not a potency): 4.65%
Compound 4: middle estimate off by 7.4 percentage points, on the high side; the measured number falls inside the stated range.
By their numbers in this assay, from the lowest: compounds 1, 4, 3 and 2 (each within the scatter of the next, the first and the last beyond it).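

With hydroxy in place of 2-hydroxyethyl on the saturated chain carbon bound to an aromatic carbon, this assay gives a step of a number 10.1 percentage points lower from compound 2 to compound 4 (beyond the scatter) and so shows that a hydroxy alone does not carry the higher number seen earlier. Hydroxy in place of heptyl gives a step of a number 2.4 percentage points higher from compound 1 to compound 4 (within the scatter) and hydroxy in place of ethyl a step of a number 3.7 percentage points lower from compound 3 to compound 4 (within the scatter) so the hydroxymethyl compound cannot be told apart from either chain without a hydroxy. Compound 2 now stands clear of both compound 1 and compound 4, though not of compound 3.

Nothing available accounts for the difference between these two hydroxy-bearing chains. As far as these compounds go, whether an amine or a carboxylic acid on the same chain, or a hydroxy on a longer chain, would raise the number further remains open.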